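Methoxy addition in a hydroxylated series: cytotoxicity notes

A few compounds are considered here, and "the series" means these few. Any claim that something is new, unique, unknown or untested is made for them only; others in the source may bear on it.

Measured so far:
compound 1 `Oc1cccc(/C=C/c2cc(O)ccc2O)c1` — 10500 nM
compound 2 `COc1ccc(/C=C/c2cccc(O)c2)c(OC)c1` — 19600 nM
compound 3 `COc1ccc(/C=C/c2cc(O)ccc2O)cc1O` — a limit only, see below

In an ADME assay on NIH3T3 cells (Mus musculus) for cytotoxicity, read by colorimetric assay and sulforhodamine B assay, with a stated time of 96 h (on this read-out lower numbers stand for stronger inhibition and higher numbers for weaker inhibition), compound 1 gives 10500 nM. Compound 2 gives 19600 nM in this assay; the values of compound 1 and compound 2 lie within the usual scatter of each other, so no order between them is read here. For compound 3 the assay reports only a limit, > 30000 nM, and not a number.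

Among the measured compounds shown here, the one counted step in the set is methoxy in place of hydrogen on an aromatic carbon, which gives an at least 2.8-fold higher number from compound 1 to compound 3 (0.45 log units; beyond the scatter). Its size is known only as a lower bound because of the limit of > 30000 nM in this assay, at which 1 of the 3 values shown sits. How the core of compound 1 and the core of compound 2 differ is not broken down here.

Compound 4 `COc1ccc(/C=C/c2ccc(OC)c(O)c2)c(OC)c1` has not yet been measured in this assay. From compound 2 it differs by methoxy in place of hydrogen on an aromatic carbon; the place reads the same, word for word, as for the step from compound 1 to compound 3, so it is the same change. For the measured compounds named here, on two examples only, the expectation rests on that single measured step, the one from compound 1 to compound 3. Compound 2 starts from 19600 nM. Compound 4 is expected to move by a 2.3-fold higher number from compound 2 to compound 4 (0.36 log units; beyond the scatter). That would put it at or beyond the limit. The estimate for compound 4 in this assay is 45000 nM, with a range from 15000 nM to 120000 nM, and a limit rather than a number is the more likely outcome.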

Compound 4, half-maximal inhibitory concentration: 2100 nM
Beside the measured number, compound 4's estimate is 21-fold (1.33 log units) above it; the whole stated range lies above it.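

Carrying methoxy in place of hydrogen on an aromatic carbon from one core to another does not preserve the direction of the step in this assay, where the second example gives a 9.3-fold lower number from compound 2 to compound 4 (0.97 log units; beyond the scatter), and the two examples disagree: the same change on two cores in this assay, an at least 2.8-fold higher number (0.45 log units; beyond the scatter) from compound 1 to compound 3 and a 9.3-fold lower number (0.97 log units; beyond the scatter) from compound 2 to compound 4, at least 26-fold (1.42 log units) apart, beyond the scatter of two such steps.

The earlier step is known only as a lower bound, with compound 3 standing at a limit and not a number: the limit of > 30000 nM in this assay, at which 1 of the 4 values shown sits.

The place reads the same in both steps, ortho to a hydroxy group and para to a large group, so the printed description of the place does not separate them, but these two pairs do not show which feature of the cores goes with the opposite outcomes, and two examples support no general rule for the series.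

Still open, as far as these compounds go, is whether a third core would follow compound 3, compound 4 or neither, and whether the change holds its direction in any read-out other than this cytotoxicity measure. Also open, from the compounds shown here alone, is how an ethoxy group, an amine or a carboxylic acid in that same place would compare with methoxy on each core.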